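Moving the Trifluoromethyl Group Around Its Ring

The compounds below may be only part of what the source reports. "The series", "measured", "known", "first", "only" and "open" are said of these compounds alone.

Compound 1 `O=C1NN(c2ccccc2)C(=O)/C1=C/c1cccc(OCc2cccc(F)c2)c1` and compound 2 `O=C1NN(c2ccccc2)C(=O)/C1=C/c1cccc(OCc2cccc(C(F)(F)F)c2)c1` share one core. In a functional assay on cells for agonist activity at Bile acid receptor (Homo sapiens), read by a luciferase reporter (a higher number here means that more compound is needed for the effect, a lower number that less compound is needed), compound 1 gives 4790 nM, and compound 2 gives 6920 nM. Among the measured compounds shown here, compound 2 has the highest of the two numbers, yet the only other compound, compound 1, sits within the scatter of it: a 1.4-fold higher number from compound 1 to compound 2 (0.16 log units; within the scatter). Compound 3 `O=C1NN(c2ccccc2)C(=O)/C1=C/c1cccc(OCc2ccc(C(F)(F)F)cc2)c1` differs from compound 2 by 4-(trifluoromethyl)phenyl in place of 3-(trifluoromethyl)phenyl on a saturated chain carbon bound to an oxygen on an aromatic ring. For the measured compounds named here, no measured step moves a group around a ring, and the one step known, a 1.4-fold higher number from compound 1 to compound 2 (0.16 log units; within the scatter), is small, so no change beyond the scatter is expected. Compound 3 is therefore estimated at 6900 nM, between 2500 nM and 19000 nM, a step of a 1.0-fold lower number from compound 2 to compound 3 (0.00 log units; within the scatter).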

Compound 3, half-maximal effective concentration: 2040 nM
For compound 3 the middle estimate is 3.4-fold (0.53 log units) above the measured one; the whole stated range lies above it.
By their numbers in this assay, from the lowest: compound 3; then compounds 1 and 2 (each within the scatter of the next).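

In this assay, the place of the trifluoromethyl group on its ring changes the number, even though the atoms stay the same: 4-(trifluoromethyl)phenyl in place of 3-(trifluoromethyl)phenyl gives a 3.4-fold lower number from compound 2 to compound 3 (0.53 log units; beyond the scatter). The same group also separates from 3-fluorophenyl, with a 2.3-fold lower number from compound 1 to compound 3 (0.37 log units; beyond the scatter), whereas the earlier swap of fluoro for trifluoromethyl stayed within the scatter. Nothing available here explains why this move of the group matters. Still open, from the compounds shown here alone, is whether a fluoro group moved the same way would follow, and how a nitrile or a carboxylic acid in place of the trifluoromethyl would read.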